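Swapping 3-bromophenyl for 3-fluoro-5-methoxyphenyl

The compounds below may be only part of what the source reports. "The series", "measured", "known", "first", "only" and "open" are said of these compounds alone.

Measured in a physicochemical assay for solubility, at pH 7.4; on this read-out higher numbers stand for higher solubility and lower numbers for lower solubility:
Compound 1 `CCOC(=O)c1c(-c2cccc(Cl)c2)[nH]c2cc(OC)c(F)cc2c1=O` gives 20000 nM here
Compound 2 `CCOC(=O)c1c(-c2cccc(Br)c2)[nH]c2cc(OC)c(F)cc2c1=O` gives 7300 nM here

Of these two compounds, compound 2 holds the lower number, and compound 1 stands above it by a margin beyond the scatter. The unmeasured compound 3 `CCOC(=O)c1c(-c2cc(F)cc(OC)c2)[nH]c2cc(OC)c(F)cc2c1=O` carries 3-fluoro-5-methoxyphenyl in place of 3-bromophenyl on an aromatic carbon next to the ring nitrogen and ortho to an ethoxycarbonyl group. Among the compounds with values here, only one measured step bears on this change, and only loosely. Bromo in place of chloro on an aromatic carbon gave a 2.7-fold lower number from compound 1 to compound 2 (0.44 log units; beyond the scatter) and that step is modest. Within the data shown here, no measured compound carries the incoming group, so the direction rests on little. Among the measured compounds shown here, with compound 2 at 7300 nM as the lower of the two readings, a modest move toward a higher number is expected, of about the size of the one measured step. The expected step is a 1.6-fold higher number from compound 2 to compound 3 (0.22 log units; within the scatter) and it is only a rough estimate. Compound 3 is thus expected at 12000 nM within an estimated range of 4000 nM to 30000 nM in this assay when it is measured.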

Compound 3, solubility: 7500 nM
For compound 3 the middle estimate is 1.6-fold (0.20 log units) above the measured one; the range from low to high includes it.
By their numbers in this assay, from the lowest: compounds 2 and 3 (each within the scatter of the next); then compound 1.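

In this assay, the aromatic carbon next to the ring nitrogen now carries a phenyl group with two substituents, and 3-fluoro-5-methoxyphenyl in place of 3-bromophenyl gives a 1.0-fold higher number from compound 2 to compound 3 (0.01 log units; within the scatter), so this read-out does not separate the two compounds even though the entering group adds a hydrogen-bond acceptor. Set against 3-chlorophenyl at the same position, the same group gives a 2.7-fold lower number from compound 1 to compound 3 (0.43 log units; beyond the scatter), a modest step beyond the scatter, which leaves compound 1 apart from both compound 2 and compound 3. Nothing in the available data accounts for either step.

The compounds shown leave open what an amine or a carboxylic acid on this phenyl ring would do to the number, as every group seen at this position so far is a halogen- or methoxy-bearing phenyl. They also leave open whether the gap between 3-chlorophenyl and the other two groups would persist if the ethoxycarbonyl group were exchanged for a carboxylic acid or a longer ester chain.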